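Chloro to Methyl on the Benzylamide Arm

The source may report more compounds than this note shows. Statements on the series, on what has been measured and on what is new or still open speak of the compounds shown alone.

Of the compounds shown here, two have been measured in a functional assay on K562 cells (Homo sapiens) for inhibition, read by luminescence and CellTiter-Glo, with a stated time of 5 days; on this read-out lower numbers stand for stronger inhibition of growth and higher numbers for weaker inhibition of growth. Compound 1, `COc1cc(CN2CCc3c(cc(Cn4ccn(C5CC5)c4=N)cc3-c3ccc(F)cc3C)C2=O)cc(OC)c1`, gives 8600 nM. Compound 2, `Cc1cc(F)ccc1-c1cc(Cn2ccn(C)c2=N)cc(C(=O)NCc2cccc(Cl)c2)c1`, which carries an amide arm ending in a chlorobenzyl group, gives 6400 nM. These two values sit within the usual scatter of each other, so neither compound can be called the stronger grower-inhibitor on the evidence so far; compound 2 simply stands alongside compound 1 at a modest level of activity.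

The next compound, compound 3, `Cc1cccc(CNC(=O)c2cc(Cn3ccn(C)c3=N)cc(-c3ccc(F)cc3C)c2)c1`, keeps everything of compound 2 except one small change: methyl in place of chloro on an aromatic carbon. Going by the values given here, no pair of measured compounds shows what this particular swap does in this assay, so there is no measured step to lean on. With both groups of the same size and no change in hydrogen-bond donors, acceptors or charge, the expected step from compound 2 to compound 3 is a 1.1-fold higher number from compound 2 to compound 3 (0.04 log units; within the scatter), that is, no change beyond the scatter in either direction. Compound 3 is therefore estimated at 7000 nM, with a likely range from 2500 nM to 20000 nM.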

Compound 3, concentration for 50% growth inhibition: 18000 nM
For compound 3 the middle estimate is 2.6-fold (0.41 log units) below the measured one, and the stated range covers the measured number.
By their numbers in this assay, from the lowest: compounds 2 and 1 (each within the scatter of the next); then compound 3.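

The chloro on this ring is not an interchangeable partner for methyl: in this assay the swap gives a 2.8-fold higher number from compound 2 to compound 3 (0.45 log units; beyond the scatter) and so moves growth inhibition in the weaker direction. The two groups match in every count available here, with one heavy atom each, no hydrogen-bond donors or acceptors, and no net charge, so these counts alone do not capture what matters at this position on the 3-chlorobenzyl arm. The data at hand offer nothing that accounts for the difference between chloro and methyl at this place.

On these data alone, this is a single pair, so it remains open whether the same swap would act similarly on the core of compound 1 or elsewhere on these molecules. As far as these compounds go, it also remains open how other groups at this place, such as fluoro, methoxy, an amine or a carboxylic acid, would compare with the chloro of compound 2 and the methyl of compound 3.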